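Benzylamino for Benzylsulfanyl on a Nucleoside Core

This account rests on a few compounds, and the source may have more. Where it says the series, first, only, none or still open, it means among the compounds named here.

Measured so far:
compound 1, `OC[C@H]1OC(n2cnc3c(SCc4ccccc4)nccc32)[C@H](O)[C@@H]1O` — 30%
compound 2, `[O-][n+]1ccc2[nH]cnc2c1` — 5%
compound 3, `OC[C@H]1O[C@@H](n2cnc3cnccc32)[C@H](O)[C@@H]1O` — < 5%; < 5% (2 entries)

In a functional assay on EL4 cells (Mus musculus) for inhibition, tested at 100 uM (a higher number here means more inhibition at the concentration tested (going by the name of the read-out), a lower number less inhibition), compound 1 gives 30%, the highest of the two numbers recorded. Compound 2 gives 5% in this assay, a gap beyond the usual scatter. For compound 3 the result is a limit of the assay, < 5%; < 5% (2 entries), and not a number. Going by the values given here, no pair of measured compounds differs in one place only, so no measured step calibrates the change ahead. Compound 4, `OC[C@H]1OC(n2cnc3c(NCc4ccccc4)nccc32)[C@H](O)[C@@H]1O`, differs from compound 1 by benzylamino in place of benzylsulfanyl on an aromatic carbon. Without a comparable measured step, a change in this assay of about the size of the scatter is expected, in either direction. Compound 4 is expected to give 25%, with a range from 5% to 50%. The step of a number 5 percentage points lower from compound 1 to compound 4 (within the scatter) is thus estimated to stay within the scatter.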

Compound 4, a percentage reported as inhibition, at one concentration (the size of the read-out at that concentration, not a potency): 5%
Estimate against measurement, compound 4: 20 percentage points above, within the range that was stated.
By their numbers in this assay, from the lowest: compounds 2 and 4 (each within the scatter of the next); then compound 1.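

In this assay, going by these compounds alone, benzylamino in place of benzylsulfanyl on an aromatic carbon next to the ring nitrogen gives a number 25 percentage points lower from compound 1 to compound 4 (beyond the scatter), the first measured step. The two groups have the same heavy-atom count and the same carbon-only aromatic ring, so a change of the linking atom, with a hydrogen-bond donor entering, is enough at this position to give a step beyond the scatter. No measurement at hand bears on the cause of this step. Open, going by these compounds, is whether benzyloxy, or a longer chain such as phenylethylsulfanyl, on the same carbon would keep the inhibition seen with compound 1.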